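Naphthyl Replacing Hydroxyphenyl on a Shared Core

The compounds below may be only part of what the source reports. "The series", "measured", "known", "first", "only" and "open" are said of these compounds alone.

Measured compounds:
compound 1, `Oc1cccc(C(c2c[nH]c3ccc(Br)cc23)c2c[nH]c3ccc(Br)cc23)c1`, gives 3900 nM in a functional assay on HeLa cells (Homo sapiens) for inhibition, read by MTT assay, with a stated time of 48 h; on this read-out lower numbers stand for stronger inhibition and higher numbers for weaker inhibition
compound 2, `COc1ccc(OC)c(C(c2c[nH]c3ccc(Br)cc23)c2c[nH]c3ccc(Br)cc23)c1`, gives 5100 nM
compound 3, `CN(C)c1ccc(C(c2c[nH]c3ccc(Br)cc23)c2c[nH]c3ccc(Br)cc23)cc1`, gives 12800 nM

Compound 1 stands at the lowest of the three numbers in this assay. Its nearest neighbour is compound 2, reached by a 1.3-fold higher number from compound 1 to compound 2 (0.12 log units; within the scatter), which is within the scatter, so the two cannot be ordered. Compound 3 lies furthest away, reached by a 3.3-fold higher number from compound 1 to compound 3 (0.52 log units; beyond the scatter), a modest step beyond the scatter; the corresponding step of a 2.5-fold higher number from compound 2 to compound 3 (0.40 log units; beyond the scatter) points the same way.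

Compound 4, `Brc1ccc2[nH]cc(C(c3ccc4ccccc4c3)c3c[nH]c4ccc(Br)cc34)c2c1`, has not yet been measured. It differs from compound 1 as follows: naphthalen-2-yl in place of 3-hydroxyphenyl on a saturated chain carbon bound to two aromatic carbons. Both measured steps from compound 1 change the group on the saturated chain carbon bound to two aromatic carbons, and both move the number upward, one within the scatter and one modestly beyond it. Neither introduces a group like naphthalen-2-yl, so the bearing is indirect.

Compound 4 is therefore expected to give a number near or somewhat above that of compound 1, a step of about a 1.4-fold higher number from compound 1 to compound 4 (0.15 log units; within the scatter) in this assay. The estimate for compound 4 is 5500 nM, with a range from 2200 nM to 14000 nM.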

Compound 4, half-maximal inhibitory concentration: 4300 nM
Compound 4: the middle estimate sits 1.3-fold (0.11 log units) above what was measured; the measured number falls inside the stated range.
By their numbers in this assay, from the lowest: compounds 1, 4 and 2 (each within the scatter of the next); then compound 3.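

In this assay, naphthalen-2-yl in place of 3-hydroxyphenyl on the saturated chain carbon gives a 1.1-fold higher number from compound 1 to compound 4 (0.04 log units; within the scatter), so this place accepts a group with two six-membered aromatic rings and no hydrogen-bond donor or acceptor, and compound 4 cannot be told apart from compound 1. The same holds against the 2,5-dimethoxyphenyl group, with a 1.2-fold lower number from compound 2 to compound 4 (0.07 log units; within the scatter), while a 3.0-fold lower number from compound 3 to compound 4 (0.47 log units; beyond the scatter) lies modestly beyond the scatter, which leaves compound 3, with its 4-(dimethylamino)phenyl group, as the only one of the four that stands apart from all the others. No measurement is available that would explain why these groups fall together or why compound 3 stands apart.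

The compounds shown leave open how a plain phenyl ring, or a phenyl ring carrying a carboxylic acid or an aminomethyl group, would compare on this carbon. On these data alone, all four compounds also keep the shared core with its two bromine atoms, so the part those atoms play in these numbers remains unknown.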